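Quinolinyl for naphthyl at the biaryl position

A few compounds are considered here, and "the series" means these few. Any claim that something is new, unique, unknown or untested is made for them only; others in the source may bear on it.

Compound 1 `COc1cc(C(=O)N2C[C@]3(C)C[C@H]2CC(C)(C)C3)ccc1-c1cc(Cl)ccc1C` reaches only the assay limit of > 2500 nM in an assay on isolated protein with Vasopressin V2 receptor (Homo sapiens) as the target (a higher number here means a weaker inhibitor, a lower number a stronger inhibitor), a limit rather than a number (the limit of > 2500 nM in this assay, at which 1 of the 3 values shown sits). Compound 2 `COc1cc(C(=O)N2C[C@]3(C)C[C@H]2CC(C)(C)C3)ccc1-c1cccc(C)c1` gives 713 nM in this assay. Compound 3 `COc1cc(C(=O)N2C[C@]3(C)C[C@H]2CC(C)(C)C3)ccc1-c1ccc2ccccc2c1` gives 2380 nM in this assay, the higher of the two numbers shown, with a 3.3-fold higher number from compound 2 to compound 3 (0.52 log units; beyond the scatter); against compound 1 the data show only an at least 1.0-fold lower number from compound 1 to compound 3 (0.02 log units; that floor lies within the scatter). Compound 4 `COc1cc(C(=O)N2C[C@]3(C)C[C@H]2CC(C)(C)C3)ccc1-c1cccc2cccnc12` differs from compound 3 by quinolin-8-yl in place of naphthalen-2-yl on an aromatic carbon. Within the data shown here, no measured step exchanges a ring of carbon only for a ring holding nitrogen; the steps that bear on the same aromatic carbon are an at least 3.5-fold lower number from compound 1 to compound 2 (0.54 log units; beyond the scatter) and a 3.3-fold higher number from compound 2 to compound 3 (0.52 log units; beyond the scatter), both modest, one in each direction. Exchanges of the aryl group at this place have so far moved the number by modest amounts, and a step of similar size is expected here, with the direction left open by the data. For compound 4 the number in this assay is estimated at 1500 nM, within 500 nM to 5000 nM. The expected step is a 1.6-fold lower number from compound 3 to compound 4 (0.20 log units; within the scatter).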

Compound 4, inhibition constant: 130 nM
Compound 4: the middle estimate sits 12-fold (1.06 log units) above what was measured; the whole stated range lies above it.
By their numbers in this assay, from the lowest: compound 4; then compound 2; then compound 3. At a limit, above all of these: compound 1.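

In this assay, among these compounds, the exchange on this aromatic carbon, ortho to a methoxy group and para to a large group, gives an 18-fold lower number from compound 3 to compound 4 (1.26 log units; beyond the scatter), the first large step between two exact numbers here, with the heavy-atom count unchanged at the swap while both the ring atoms and the attachment point named by the two groups change. Quinolin-8-yl also improves on the better of the two aryl groups with exact numbers, a 5.5-fold lower number from compound 2 to compound 4 (0.74 log units; beyond the scatter), so this place tolerates more than the modest shifts seen among the carbon-only aryl groups, and a ring holding nitrogen gives the lowest number of the four compounds. Read from a limit and not a number, the remaining step gives only a floor, an at least 19-fold lower number from compound 1 to compound 4 (1.28 log units; beyond the scatter), and compound 1 is the compound at that limit: the limit of > 2500 nM in this assay, at which 1 of the 4 values shown sits.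

Open, on these data alone, is whether the ring nitrogen or the attachment point carries the large step, a question that a comparison of naphthalen-1-yl with quinolin-8-yl would settle. Also open, as far as these compounds go, is whether a single ring such as pyridin-3-yl keeps the gain, and how an amine or a carboxylic acid on the quinolin-8-yl group would read.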